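Chloro Added Where Both Measured Compounds Sit at the Limit

The source may report more compounds than this note shows. Statements on the series, on what has been measured and on what is new or still open speak of the compounds shown alone.

Measured compounds:
compound 1 `CCn1cc(-c2nc3ccccc3[nH]2)c(=O)c2cc(F)c(N3CCNCC3)cc21` — > 10000 nM
compound 2 `CCn1cc(-c2nc3ccccc3[nH]2)c(=O)c2cc(F)c(N3CCNCC3)nc21` — > 10000 nM

In a functional assay on THP-1 cells (Homo sapiens) for cytotoxicity, read by sulforhodamine B assay, with a stated time of 48 h (on this read-out higher numbers stand for weaker inhibition and lower numbers for stronger inhibition), compound 1 gives > 10000 nM, which is a limit of the assay rather than a number. Compound 2 gives > 10000 nM in this assay, again a limit. Compound 1 therefore stands nowhere above or below any other measured compound: the limit of > 10000 nM in this assay, at which 2 of the 2 values shown sit, so the two values show no difference that can be read. Compound 3 `CCn1cc(-c2nc3ccc(Cl)cc3[nH]2)c(=O)c2cc(F)c(N3CCNCC3)cc21` is the compound still to be measured. It differs from compound 1 by chloro in place of hydrogen on an aromatic carbon. For the measured compounds named here, no step between measured compounds exists to calibrate this change, and the only measured values are limits. The account expects no step beyond the scatter in this assay, and expects the step that the limit leaves unreadable from compound 1 to compound 3 to be small. Compound 3 is estimated at 15000 nM, between 3000 nM and 60000 nM, most likely reported as a limit again.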

Compound 3, half-maximal inhibitory concentration: 2800 nM
The estimate for compound 3 lay 5.4-fold (0.73 log units) above the measured number; the whole stated range lies above it.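

The change shows that this place on the benzimidazole is not silent in this assay: chloro in place of hydrogen on an aromatic carbon gives an at least 3.5-fold lower number from compound 1 to compound 3 (0.55 log units; beyond the scatter). For the compounds shown here, it is the first change to bring a read-out off the limit and give a number that can be compared. The step gives only a minimum size, because the starting value of compound 1 is a limit: the limit of > 10000 nM in this assay, at which 2 of the 3 values shown sit.

Whether this shift belongs to chloro alone stays open, since the compounds shown do not tell how fluoro, methyl, methoxy or an amine would behave at this place. They also leave open whether 6-chloro-1H-benzimidazol-2-yl would lower the number in the same way on the core of compound 2, which itself gives > 10000 nM, again a limit.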